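Working notes: anilino to (naphthalen-1-yl)amino in one series

The source may report more compounds than this note shows. Statements on the series, on what has been measured and on what is new or still open speak of the compounds shown alone.

Of the compounds shown here, two have been measured. Compound 1 `C=C1[C@@H](OC(C)=O)C[C@@H]2[C@](C)(CO[Si](C)(C)C(C)(C)C)[C@H](OC(C)=O)CC[C@@]2(C)[C@@H]1C[C@@H](Nc1ccccc1F)C1=CCOC1=O` gives 4740 nM in a functional assay on KB cells (Homo sapiens) for cytotoxicity, read by sulforhodamine B assay (a higher number here means a weaker inhibitor, a lower number a stronger inhibitor), and compound 2 `C=C1[C@@H](OC(C)=O)C[C@@H]2[C@](C)(CO[Si](C)(C)C(C)(C)C)[C@H](OC(C)=O)CC[C@@]2(C)[C@@H]1C[C@@H](Nc1ccccc1)C1=CCOC1=O` gives 5710 nM in the same assay. Going by the values given here, the only measured step, a 1.2-fold higher number from compound 1 to compound 2 (0.08 log units; within the scatter), is hydrogen in place of fluoro on an aromatic carbon. Compound 2 thus holds the higher of the two numbers, but its gap to compound 1 is within the scatter, so the two read as equivalent.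

Compound 3 `C=C1[C@@H](OC(C)=O)C[C@@H]2[C@](C)(CO[Si](C)(C)C(C)(C)C)[C@H](OC(C)=O)CC[C@@]2(C)[C@@H]1C[C@@H](Nc1cccc2ccccc12)C1=CCOC1=O` differs from compound 2 by naphthalen-1-yl in place of phenyl on an amine nitrogen. Among the compounds with values here, no measured step bears directly on this change; the one step available was within the scatter and concerns a different position. On the numbers shown, the step of a 1.1-fold lower number from compound 2 to compound 3 (0.06 log units; within the scatter) is therefore expected to lie within the scatter, with wide uncertainty. Compound 3 is estimated at 5000 nM, range 1800 nM to 15000 nM.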

Compound 3, half-maximal inhibitory concentration: 8930 nM
Estimate against measurement, compound 3: 1.8-fold (0.25 log units) below; measured number inside the range.
By their numbers in this assay, from the lowest: compounds 1, 2 and 3 (each within the scatter of the next).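

In (this assay) the amine nitrogen carries naphthalen-1-yl, with its 10 heavy atoms and 2 six-membered aromatic rings, in place of phenyl, and the step stays within the scatter (a 1.6-fold higher number from compound 2 to compound 3 (0.19 log units; within the scatter)). The step from the 2-fluorophenyl group also stays within the scatter (a 1.9-fold higher number from compound 1 to compound 3 (0.28 log units; within the scatter)), so all three aryl groups on this nitrogen read as equivalent, and the added aromatic ring separates compound 3 from neither neighbour. No evidence on hand explains this flat reading.

The compounds shown leave open whether any group on this nitrogen can move the number beyond the scatter. Untested here are a saturated group such as cyclohexyl, a longer alkyl chain, and a phenyl ring bearing a carboxylic acid or an amine.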